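Changing the group on the amide nitrogen

The source may hold more compounds than are shown below. What is called first, only, known or untested is meant among the compounds shown, and "the series" means these compounds.

Compound 1 `Cc1cccc(-c2cccc(NC(=O)c3nnc(CCC(=O)O)s3)c2)c1` gives 1.28
Compound 2 `O=C(O)CCc1nnc(C(=O)Nc2cccc(-c3ccc(F)cc3)c2)s1` gives 0.96
Compound 3 `O=C(O)CCc1ccc(OCc2nnc(C(=O)Nc3ccccc3F)s2)cc1` gives 0.95

In a physicochemical assay for lipophilicity, read by LC-MS, at pH 7.4 (on this read-out lower numbers stand for lower lipophilicity and higher numbers for higher lipophilicity), compound 3 matches compound 2 within the usual scatter, and both lie clearly under compound 1. Compound 4 `O=C(O)CCc1ccc(OCc2nnc(C(=O)Nc3cccc(Cl)c3)s2)cc1` differs from compound 3 in one place: 3-chlorophenyl in place of 2-fluorophenyl on an amide-type nitrogen, which means 3-chlorophenyl in place of 2-fluorophenyl on an amide-type nitrogen. Among the compounds with values here, only one measured step bears on this swap: a number 0.32 log units lower from compound 1 to compound 2 (beyond the scatter). There a fluorophenyl group entered and the number fell, though on an aromatic carbon, so it is only a loose guide. Here a fluorophenyl group leaves, so a modest rise is expected, an estimated a number 0.30 log units higher from compound 3 to compound 4 (within the scatter) in this assay as the likely change. The estimate for compound 4 is 1.25, with an expected range of 0.9 to 1.6 as its limits.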

Compound 4, distribution coefficient: 1.46
The estimate for compound 4 lay 0.21 log units below the measured number; the range from low to high includes it.
By their numbers in this assay, from the lowest: compounds 3 and 2 (each within the scatter of the next); then compounds 1 and 4 (each within the scatter of the next).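

In this assay the group on the amide-type nitrogen clearly moves the number: 3-chlorophenyl in place of 2-fluorophenyl gives a number 0.51 log units higher from compound 3 to compound 4 (beyond the scatter) with the rest of the molecule unchanged. Within the data shown here, this is the first measured step at this nitrogen, as the earlier step lay on an aromatic carbon. Nothing shown here gives a reason for this rise. The swap changes both the halogen and its place on the ring, and 3-fluorophenyl or 2-chlorophenyl would be needed to separate the two. On these data alone, how an unsubstituted phenyl or a group carrying an amine would read at this nitrogen also stays open.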